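Replacing the piperazinylmethyl group on the shared core

The compounds below may be only part of what the source reports. "The series", "measured", "known", "first", "only" and "open" are said of these compounds alone.

The shared core is seen in compound 1 `O=C(CN1CCNCC1)N1CCC(NS(=O)(=O)c2cc(S(=O)(=O)c3ccccc3)ccc2C(F)(F)F)CC1`, whose carbonyl carries a (piperazin-1-yl)methyl group. In a physicochemical assay for solubility (on this read-out lower numbers stand for lower solubility and higher numbers for higher solubility), compound 1 gives 50000 nM, the second highest of the three numbers measured. Compound 2 `CC(C)(C)OC(=O)N1CCC[C@H]1C(=O)N1CCC(NS(=O)(=O)c2cc(S(=O)(=O)c3ccccc3)ccc2C(F)(F)F)CC1` gives 25000 nM in this assay, and compound 3 `CC(C)C(=O)N1CCC[C@H]1C(=O)N1CCC(NS(=O)(=O)c2cc(S(=O)(=O)c3ccccc3)ccc2C(F)(F)F)CC1` gives 100000 nM. The two steps from compound 1 are small: a 2.0-fold lower number from compound 1 to compound 2 (0.30 log units; within the scatter), and a 2.0-fold higher number from compound 1 to compound 3 (0.30 log units; within the scatter). Between the two pyrrolidine-bearing compounds the step is larger: a 4.0-fold higher number from compound 2 to compound 3 (0.60 log units; beyond the scatter).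

Compound 4 `CC(C)(C)CCN1CCC[C@H]1C(=O)N1CCC(NS(=O)(=O)c2cc(S(=O)(=O)c3ccccc3)ccc2C(F)(F)F)CC1` has not yet been measured in this assay. Its structural change from compound 1 is 1-(3,3-dimethylbutyl)pyrrolidin-2-yl in place of (piperazin-1-yl)methyl on a carbonyl carbon. Both measured steps from compound 1 also exchange the (piperazin-1-yl)methyl group for a pyrrolidin-2-yl group, and both stayed within the scatter, one in each direction. Neither of them, however, carries a 3,3-dimethylbutyl group on the pyrrolidine nitrogen, so the data give no direct guide for that part of the change. On this basis compound 4 is expected to move only modestly, estimated as a 2.5-fold lower number from compound 1 to compound 4 (0.40 log units; beyond the scatter), with the direction leaning slightly downward. The estimated value for compound 4 in this assay is 20000 nM, with a range from 5000 nM to 80000 nM.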

Compound 4, solubility: 12500 nM
Compound 4: middle estimate off by 1.6-fold (0.20 log units), on the high side; measured number inside the range.
By their numbers in this assay, from the lowest: compounds 4, 2, 1 and 3 (each within the scatter of the next, the first and the last beyond it).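

In this assay, the exchange on the carbonyl carbon now produces a step from compound 1 that is beyond the scatter, a 4.0-fold lower number from compound 1 to compound 4 (0.60 log units; beyond the scatter), whereas the two earlier exchanges at this place stayed within it. The new compound also shows that, on an amine nitrogen in a ring, the outcome of introducing 3,3-dimethylbutyl depends on the group it replaces: in place of isopropylcarbonyl it gives an 8.0-fold lower number from compound 3 to compound 4 (0.90 log units; beyond the scatter), the largest step in this small set, while in place of tert-butoxycarbonyl it gives a 2.0-fold lower number from compound 2 to compound 4 (0.30 log units; within the scatter), which stays within the scatter. No measurement bears on why these steps differ in size.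

The compounds shown leave open whether the lower number of compound 4 belongs to the 3,3-dimethylbutyl chain as such, since a shorter alkyl chain such as ethyl on the same nitrogen would separate chain length from the loss of the carbonyl. They also leave open how a terminal amine or carboxylic acid on that chain would read in this assay.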